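A few compounds are considered here, and "the series" means these few. Any claim that something is new, unique, unknown or untested is made for them only; others in the source may bear on it.

Compound 1, with the structure `NC(=O)CC[C@H](NC(=O)CN(c1ncnc2c1ncn2C1CCCCO1)C1CC1)C(=O)OCc1ccccc1`, was tested in a functional assay on the whole organism (Tail, strain ICR) with Mus musculus as the target, in the tail flick test, with a stated time of 60 min, at a dose of 25 umol/kg by the oral route (a higher number here means a stronger effect of the compound at the dose given, a lower number a weaker effect), and gave 39.4%. This is the higher of the two numbers in hand, though its companion compound 2, with the structure `CC[C@H](C)[C@H](NC(=O)CN(c1nc(Cl)nc2[nH]cnc12)C1CC1)C(=O)O`, gave 36% in this assay, a result within the usual scatter of compound 1, so the two cannot be ranked against each other. Compound 3, with the structure `C[C@H](NC(=O)CN(c1ncnc2c1ncn2C1CCCCO1)C1CC1)C(=O)OCc1ccccc1`, remains to be measured in this assay. It differs from compound 1 in one place: hydrogen in place of carbamoylmethyl on a saturated chain carbon, two bonds along the chain from an amide-type nitrogen and a carbonyl carbon. For the measured compounds named here, no pair of measured compounds separated by a single change is available to calibrate a step of this kind, so the direction of the step from compound 1 to compound 3 rests on the structural change alone. The step of a number 8.4 percentage points lower from compound 1 to compound 3 (within the scatter) is expected to stay within the usual scatter. Compound 3 is therefore estimated to give 31% in this assay, within a range from 12% to 50%.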

Compound 3, a percentage reported as activity, at one dose (the size of the read-out at that dose, not a potency): 53%
Beside the measured number, compound 3's estimate is 22 percentage points below it; measured number above the stated range.
By their numbers in this assay, from the lowest: compounds 2 and 1 (each within the scatter of the next); then compound 3.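

In this assay, putting hydrogen in place of carbamoylmethyl on a saturated chain carbon, two bonds along the chain from an amide-type nitrogen and a carbonyl carbon, gives a number 13.6 percentage points higher from compound 1 to compound 3 (beyond the scatter). For the compounds shown here, this is the first change in these compounds that can be read at a single position, and it shows that the 2-carbamoylethyl chain can be cut back to methyl without losing the effect at this dose; the effect in fact rises. Nothing at hand accounts for this rise.

Going by these compounds, whether a carboxylic acid, an amine or a longer hydrocarbon chain at this position would read like carbamoylmethyl or like hydrogen remains open. Also open, on these data alone, is whether the same step would hold on the core of compound 2, with its different ester-free acid end.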